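The source may hold more compounds than are shown below. What is called first, only, known or untested is meant among the compounds shown, and "the series" means these compounds.

Measured so far in a physicochemical assay for pharmacokinetics; on this read-out higher numbers stand for a longer-lived compound and lower numbers for a shorter-lived compound:
compound 1, `O=C(NCc1ccc(C(F)(F)F)cc1)N1C(=O)c2ccccc2S1(=O)=O`: > 166 h
compound 2, `O=C(NCc1ccccc1C(F)(F)F)N1C(=O)c2ccccc2S1(=O)=O`: > 166 h
compound 3, `O=C(NCc1cccc2ccccc12)N1C(=O)c2ccccc2S1(=O)=O`: > 166 h

In this assay compound 1 gives > 166 h, which is a limit of the assay and not a number. Compound 2 gives > 166 h in this assay, again a limit. Compound 3 gives > 166 h in this assay, also a limit. Compound 2 thus stands where every value of the series stands, at the limit of > 166 h in this assay, at which 3 of the 3 values shown sit. Within the data shown here, no compound has a numeric half-life, so no step between measured compounds can be sized, and nothing separates the three from one another.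

The unmeasured compound 4, `O=C(NCc1ccccc1Cl)N1C(=O)c2ccccc2S1(=O)=O`, differs from compound 2 in one place: chloro in place of trifluoromethyl on an aromatic carbon. The rest of the structure is unchanged.

Every value shown in this assay sits at the limit, including compound 2 with > 166 h. On that basis the expected step in this assay is an at least 1.1-fold lower number from compound 2 to compound 4 (0.07 log units; that floor lies within the scatter), none beyond the usual scatter. Compound 4 is expected to give about 140 h in this assay, in the range 50 h to 300 h, with a fair chance that the assay again reports only a limit.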

Compound 4, half-life: > 166 h
Compound 4: a limit, no number; the forecaster's own chance of this, stated with the estimate: 65%; middle value at least 1.1-fold (0.07 log units) from the limit.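

In this assay compound 4 gives > 166 h, a limit of the assay and not a number. Among these compounds, compound 2 also sits at a limit, so no step from chloro in place of trifluoromethyl can be read between compound 2 and compound 4: the limit of > 166 h in this assay, at which 4 of the 4 values shown sit. The compounds shown leave open whether the two groups differ at all in this assay.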